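The compounds below may be only part of what the source reports. "The series", "measured", "known", "first", "only" and "open" are said of these compounds alone.

Measured in a functional assay on MCF7 cells (Homo sapiens) for cytotoxicity, read by MTT assay, with a stated time of 96 h; a lower number here means a stronger inhibitor, a higher number a weaker inhibitor:

- Compound 1 `COc1cc(C(=O)c2cn(-c3ccccc3)cc2-c2ccc(N)cc2)cc(OC)c1OC` gives 9 nM
- Compound 2 `COc1cc(C(=O)c2cn(-c3ccccc3)cc2-c2ccccc2[N+](=O)[O-])cc(OC)c1OC` gives 49 nM
- Compound 3 `COc1cc(C(=O)c2cn(-c3ccccc3)cc2-c2cc(F)ccc2F)cc(OC)c1OC` gives 230 nM

Compound 2 stands in the middle of these three numbers, with a 5.4-fold higher number from compound 1 to compound 2 (0.74 log units; beyond the scatter) and a 4.7-fold higher number from compound 2 to compound 3 (0.67 log units; beyond the scatter). Compound 4 `COc1cc(C(=O)c2cn(-c3cccc(F)c3)cc2-c2ccccc2[N+](=O)[O-])cc(OC)c1OC` differs from compound 2 by one change, (fluoro in place of hydrogen on an aromatic carbon), which is fluoro in place of hydrogen on an aromatic carbon, turning phenyl into 3-fluorophenyl. Going by the values given here, no measured step touches that phenyl. The closest guide is a 26-fold higher number from compound 1 to compound 3 (1.41 log units; beyond the scatter), and it and the two steps above only swap the 4-aminophenyl, 2-nitrophenyl and 2,5-difluorophenyl groups. They show that the series can respond strongly, but not how it responds to this change. In this assay no step beyond the scatter is therefore expected, and no direction is clearly favoured. The expected change is a 1.2-fold higher number from compound 2 to compound 4 (0.09 log units; within the scatter). For compound 4 the estimated value is 60 nM, with an expected range from 15 nM to 220 nM.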

Compound 4, half-maximal inhibitory concentration: 190 nM
Compound 4: the middle estimate sits 3.2-fold (0.50 log units) below what was measured; low and high end bracket the measured number.
By their numbers in this assay, from the lowest: compound 1; then compound 2; then compounds 4 and 3 (each within the scatter of the next).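

Going by these compounds alone, this is the first measured change on the phenyl ring that compounds 1, 2 and 3 share, and in this assay adding one fluoro, meta to a large group, gives a 3.9-fold higher number from compound 2 to compound 4 (0.59 log units; beyond the scatter), a step towards weaker inhibition. This ring is therefore not a silent part of the molecule, at least with the 2-nitrophenyl group in place. Nothing measured here explains the step.

From the compounds shown here alone, whether any group at this place would act the same way remains open, for example chloro or methoxy. Also unknown is whether fluoro would have the same effect in compound 1, which carries 4-aminophenyl.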